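Notes on replacing the acyl group of compound 2

A few compounds are considered here, and "the series" means these few. Any claim that something is new, unique, unknown or untested is made for them only; others in the source may bear on it.

Measured in a functional assay on MGC-803 cells (Homo sapiens) for inhibition, read by MTT assay, with a stated time of 48 h; on this read-out higher numbers stand for weaker inhibition and lower numbers for stronger inhibition:
- compound 1 `C/C=C/C(=O)N(Cc1ccc(OC)c([N+](=O)[O-])c1)c1cc(OC)c(OC)c(OC)c1`: 590 nM
- compound 2 `COCC(=O)N(Cc1ccc(OC)c(O)c1)c1cc(OC)c(OC)c(OC)c1`: 79 nM
- compound 3 `C/C=C/C(=O)N(Cc1ccc(OC)c(OC)c1)c1cc(OC)c(OC)c(OC)c1`: 20100 nM

Compound 2, at 79 nM, has the lowest number of the three and stands clearly apart from both others. The next step leads to compound 4 `C/C=C/C=C/C(=O)N(Cc1ccc(OC)c(O)c1)c1cc(OC)c(OC)c(OC)c1`, with penta-1,3-dien-1-yl in place of methoxymethyl on a carbonyl carbon. The rest of compound 2 stays unchanged.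

Within the data shown here, only one single-place step has been measured in this assay: a 34-fold higher number from compound 1 to compound 3 (1.53 log units; beyond the scatter), a large step with methoxy in place of nitro on an aromatic carbon. It lies at a different place, so it gives no direct size or direction for this change. Among the measured compounds shown here, it shows only that one change can move this series far. Since compound 2 already sits lowest at 79 nM, a moderate upward move is the more likely outcome, though with wide uncertainty. The expected step is a 2.5-fold higher number from compound 2 to compound 4 (0.40 log units; beyond the scatter). For compound 4 the estimated value is 200 nM, with an expected range of 40 nM to 1000 nM.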

Compound 4, half-maximal inhibitory concentration: 140 nM
For compound 4 the middle estimate is 1.4-fold (0.15 log units) above the measured one, within the range that was stated.
By their numbers in this assay, from the lowest: compounds 2 and 4 (each within the scatter of the next); then compound 1; then compound 3.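

At this carbonyl carbon, this assay gives a 1.8-fold higher number from compound 2 to compound 4 (0.25 log units; within the scatter) and so does not separate methoxymethyl from penta-1,3-dien-1-yl. The acyl position therefore accepts a longer all-carbon chain with double bonds in place of methoxymethyl, and the oxygen of methoxymethyl is not needed for compound 4 to stay within the scatter of compound 2. No measurement at hand accounts for this result.

Still open, going by these compounds, is how far this tolerance extends on the same carbonyl carbon, for example to an aminomethyl group, a chain ending in a carboxylic acid, or a saturated hexyl chain. Also open, on these data alone, is whether the large step of a 34-fold higher number from compound 1 to compound 3 (1.53 log units; beyond the scatter) would recur in compounds carrying penta-1,3-dien-1-yl on the carbonyl carbon.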